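Working notes: pyridyl ether series, orexin type 2 antagonism

The source may report more compounds than this note shows. Statements on the series, on what has been measured and on what is new or still open speak of the compounds shown alone.

Measured so far:
- compound 1, `C[C@@H]1CC[C@@H](Oc2cc(-c3ccccc3)ccn2)CN1C(=O)c1ccccc1-n1nccn1`: 45 nM
- compound 2, `COC(=O)c1ccnc(O[C@@H]2CC[C@@H](C)N(C(=O)c3ccccc3-n3nccn3)C2)c1`: 22 nM

In a functional assay on CHO-K1 cells for antagonist activity at Orexin receptor type 2 (Homo sapiens), read by FLIPR and calcium flux (a higher number here means a weaker inhibitor, a lower number a stronger inhibitor), compound 2 gives the lowest of the two numbers recorded; its nearest neighbour is compound 1, and the step of a 2.0-fold lower number from compound 1 to compound 2 (0.31 log units; beyond the scatter) lies beyond the scatter. Compound 3, `CCc1ccnc(O[C@@H]2CC[C@@H](C)N(C(=O)c3ccccc3-n3nccn3)C2)c1`, has not yet been run in this assay. It differs from compound 2 at one place: ethyl in place of methoxycarbonyl on an aromatic carbon.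

Within the data shown here, only one measured step exists, a 2.0-fold lower number from compound 1 to compound 2 (0.31 log units; beyond the scatter), and it concerns a different exchange at the same aromatic carbon, phenyl giving way to methoxycarbonyl. Among the measured compounds shown here, it says nothing direct about ethyl in place of methoxycarbonyl; it shows only that the two groups tried so far at that carbon differ by a modest margin, with methoxycarbonyl the lower of the two. For the measured compounds named here, no measured step pairs methoxycarbonyl against a group with no hydrogen-bond acceptors. The expectation therefore rests on the spread seen between compound 1 and compound 2, and a step of about that size, toward a higher number, is expected from compound 2 to compound 3, a 1.8-fold higher number from compound 2 to compound 3 (0.26 log units; within the scatter). Compound 3 is estimated at 40 nM, with a range of 15 nM to 120 nM.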

Compound 3, half-maximal inhibitory concentration: 11 nM
The estimate for compound 3 lay 3.6-fold (0.56 log units) above the measured number, outside the stated range (below it).
By their numbers in this assay, from the lowest: compounds 3 and 2 (each within the scatter of the next); then compound 1.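

In this assay, ethyl in place of methoxycarbonyl on the aromatic carbon opposite the ring nitrogen gives a 2.0-fold lower number from compound 2 to compound 3 (0.30 log units; within the scatter) and so leaves compound 2 and compound 3 not separated. Ethyl has 0 hydrogen-bond acceptors and methoxycarbonyl has 2, so in this pair the acceptors of methoxycarbonyl are not needed for a number of this size, which the earlier pair could not show. Ethyl in place of phenyl gives a 4.1-fold lower number from compound 1 to compound 3 (0.61 log units; beyond the scatter) and, with the earlier step from phenyl to methoxycarbonyl, sets compound 1 apart as the one compound beyond the scatter from both others. No measurement on hand accounts for these numbers.

As far as these compounds go, whether the number stays in this range with a longer chain such as propyl, or with a methoxy group, an amine or a carboxylic acid at this carbon, remains open. Also open, from the compounds shown here alone, is whether the 4-ethylpyridin-2-yl group would give a similar result with any change elsewhere in the shared core, as all three compounds vary at this one carbon only.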